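Repeating a Methyl Step on a Second Core

The compounds below may be only part of what the source reports. "The series", "measured", "known", "first", "only" and "open" are said of these compounds alone.

Three compounds were measured in a functional assay on the whole organism (strain Wistar) for inhibition, with Rattus norvegicus as the target, with stated times of 30 min and 3 h, at a dose of 20 mg/kg by the oral route; a lower number here means less inhibition, a higher number more inhibition at the dose given (going by the name of the read-out). Compound 1 `Cc1ccc(C(=O)CCc2nnc(-c3ccccc3Cl)o2)cc1` gives 57.3%, and compound 2 `Cc1ccc(C(=O)CCc2nnc(-c3ccccc3Cl)o2)c(C)c1` gives 60.5%. The change between them is methyl in place of hydrogen on an aromatic carbon, and it made a step of a number 3.2 percentage points higher from compound 1 to compound 2 (within the scatter). Compound 3 `Cc1ccc(C(=O)CCc2nnc(Cc3ccccc3)o2)cc1` gives 51.9%; its core differs from that of compound 1 by benzyl in place of 2-chlorophenyl on an aromatic carbon, a step of a number 5.4 percentage points lower from compound 1 to compound 3 (within the scatter). Compound 4 `Cc1ccc(C(=O)CCc2nnc(Cc3ccccc3)o2)c(C)c1` has not yet been measured. It differs from compound 3 by methyl in place of hydrogen on an aromatic carbon, the same change as between compound 1 and compound 2, made here on the core of compound 3. The step to compound 4 is expected to be a number 3.1 percentage points higher from compound 3 to compound 4 (within the scatter), because a number 3.2 percentage points higher from compound 1 to compound 2 (within the scatter) stayed within the scatter. Compound 4 is therefore estimated at 55%, with a range from 42% to 68% that reflects the spread of single-dose readings.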

Compound 4, a percentage reported as inhibition, in the whole organism at one dose (the size of the read-out at that dose, not a potency): 50%
Compound 4: middle estimate off by 5 percentage points, on the high side; measured number inside the range.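

In this assay the methyl change gave a number 1.9 percentage points lower from compound 3 to compound 4 (within the scatter), and the two cores show no difference in this step that stands out from the scatter: the same change on two cores in this assay, a number 3.2 percentage points higher (within the scatter) from compound 1 to compound 2 and a number 1.9 percentage points lower (within the scatter) from compound 3 to compound 4, 5.1 percentage points apart, within the scatter of two such steps

The change from 2-chlorophenyl to benzyl gave a number 10.5 percentage points lower from compound 2 to compound 4 (beyond the scatter), and although this step alone lies beyond the scatter, it does not differ from its counterpart on the cores without the added methyl: the same change on two cores in this assay, a number 5.4 percentage points lower (within the scatter) from compound 1 to compound 3 and a number 10.5 percentage points lower (beyond the scatter) from compound 2 to compound 4, 5.1 percentage points apart, within the scatter of two such steps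

This shows that on these two cores the methyl change carried over without a measurable difference, but with both steps within the scatter it does not show that the methyl group changes the read-out, nor that the same would hold on any other core.

The compounds shown leave open what a methoxy group or a fluorine would do in place of the added methyl. They also leave open how a longer chain would read in place of the benzyl group in this assay.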